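The compounds below may be only part of what the source reports. "The series", "measured", "known", "first", "only" and "open" are said of these compounds alone.

Compound 3 `CC1=C(C(=O)Nc2ccc(F)cc2)C(c2ccc(Cl)cc2)n2c(s/c(=C/c3ccc(Br)cc3)c2=O)=N1` stands highest of the three measured compounds in a functional assay on the whole organism (strain albino) for inhibition, with Rattus norvegicus as the target, read by paw edema, with stated times of 1 h and 3 h, at a dose of 25 mg/kg by the oral route (on this read-out lower numbers stand for less inhibition and higher numbers for more inhibition at the one dose given (going by the name of the read-out)), giving 35%. Compound 1 `COc1ccc(/C=c2/sc3n(c2=O)C(c2ccc([N+](=O)[O-])cc2)C(C(=O)Nc2ccc(F)cc2)=C(C)N=3)cc1` gives 12% in this assay, and compound 2 `CC1=C(C(=O)Nc2ccc(F)cc2)C(c2ccc([N+](=O)[O-])cc2)n2c(s/c(=C/c3ccccc3)c2=O)=N1` gives 7%. Compound 4 `CC1=C(C(=O)Nc2ccc(F)cc2)C(c2ccc(Cl)cc2)n2c(s/c(=C/c3ccccc3Cl)c2=O)=N1` has not yet been measured. It differs from compound 3 in one place: 2-chlorophenyl in place of 4-bromophenyl on a double-bonded chain carbon bound to an aromatic carbon. Among the measured compounds shown here, the only measured step that touches the same part of the molecule is a number 5 percentage points lower from compound 1 to compound 2 (within the scatter), a swap of a substituent on the ring held by the double-bonded chain carbon, and that swap stayed within the scatter. On that basis the step from compound 3 to compound 4 in this assay is expected to be a number 5 percentage points lower from compound 3 to compound 4 (within the scatter), nothing beyond the scatter. Compound 4 is therefore estimated at 30%, within a range of 15% to 45%.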

Compound 4, a percentage reported as inhibition, in the whole organism at one dose (the size of the read-out at that dose, not a potency): 16%
Compound 4: middle estimate off by 14 percentage points, on the high side, within the range that was stated.
By their numbers in this assay, from the lowest: compounds 2, 1 and 4 (each within the scatter of the next); then compound 3.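

At this place, on a double-bonded chain carbon bound to an aromatic carbon, the choice of aryl group can clearly move the result. In this assay, the change from 4-bromophenyl to 2-chlorophenyl gives a number 19 percentage points lower from compound 3 to compound 4 (beyond the scatter), whereas the earlier swap on this ring gave a number 5 percentage points lower from compound 1 to compound 2 (within the scatter). Nothing available explains the drop. This one step changes the halogen and its place on the ring together, so their shares cannot be separated. As far as these compounds go, how an amine or a carboxylic acid on this ring would fare remains open.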